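Amidine chain extension: methoxy to methoxymethyl

This account rests on a few compounds, and the source may have more. Where it says the series, first, only, none or still open, it means among the compounds named here.

Series notes. The compounds share an amidine or guanidine attached to a four-carbon chain. Compound 1 `C=CCCNC(=N)NCCCCN` gives 0% in an assay for inhibition of arginase-1 (Bos taurus), with a stated time of 30 min, tested at 1 mM; a higher number here means more inhibition at the concentration tested (going by the name of the read-out), a lower number less inhibition. Compound 2 `COCC(=N)NCCC[C@H](N)C(=O)O` gives 22%, the highest of the three numbers, though compound 3 `COCC(=N)NCCCCN` at 21% lies within the scatter of it; only compound 1 sits beyond the scatter below. Among the compounds with values here, the one single-place step measured, a number 1 percentage points lower from compound 2 to compound 3 (within the scatter), concerns the carboxy at the chain end and says nothing about the group on the amidine carbon. Within the data shown here, compound 1 and compound 3 differ at more than one place, so their two values show only that the whole change between them lowers inhibition.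

Compound 4 `COCCC(=N)NCCC[C@H](N)C(=O)O` differs from compound 2 by methoxymethyl in place of methoxy on a saturated chain carbon bound to a carbon with a double bond to nitrogen. Among the measured compounds shown here, no measured step touches this position; the change is small and adds one carbon to the chain on the amidine side. The step from compound 2 is therefore expected to stay within the scatter, estimated as a number 6 percentage points lower from compound 2 to compound 4 (within the scatter). For compound 4 the estimate in this assay is 16%, between 3% and 30%.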

Compound 4, a percentage reported as inhibition, at one concentration (the size of the read-out at that concentration, not a potency): 43%
Estimate against measurement, compound 4: 27 percentage points below, outside the stated range (above it).
By their numbers in this assay, from the lowest: compound 1; then compounds 3 and 2 (each within the scatter of the next); then compound 4.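

In this assay, within the data shown here, the saturated chain carbon bound to a carbon with a double bond to nitrogen proves sensitive to a small change: methoxymethyl in place of methoxy gives a number 21 percentage points higher from compound 2 to compound 4 (beyond the scatter) and so opens the first single-place step to lie beyond the scatter. The earlier step, a number 1 percentage points lower from compound 2 to compound 3 (within the scatter) for the exchange of carboxy for hydrogen, showed no such separation and did not touch this position. Nothing at hand accounts for the rise.

As far as these compounds go, whether a longer chain ending in methoxy would extend the rise, or an amine or a carboxylic acid at the same place would match it, remains open. Also open, from the compounds shown here alone, is whether hydrogen in place of carboxy would leave the value of compound 4 unchanged, as it does for compound 2.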